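Fluoro for Chloro on a Shared Core

This account rests on a few compounds, and the source may have more. Where it says the series, first, only, none or still open, it means among the compounds named here.

Compound 1, `CCn1c(CNc2ccccc2)nnc1SCC(=O)Nc1ccc(OC)cc1`, gives > 1000 nM in an assay on isolated protein for inhibition of long-chain fatty acid transport protein 1 (Homo sapiens); a higher number here means a weaker inhibitor, a lower number a stronger inhibitor; this is a limit of the assay, not a number.
Compound 2, `CCn1c(CNc2ccccc2)nnc1SCc1nc2cc(Cl)ccc2o1`, gives > 1000 nM; this too is a limit.
Compound 3, `CCn1c(CNc2ccccc2)nnc1SCC(=O)Nc1ccccc1`, gives > 1000 nM; again only a limit.

Compound 2 thus stands at the limit of > 1000 nM in this assay, at which 3 of the 3 values shown sit, where every measured value rests. Nothing more is known of it than that it inhibits weakly, if at all. Going by the values given here, the one comparison between measured compounds that differ in a single place is a step that the two limits leave unreadable from compound 1 to compound 3; both ends sit at the limit, so its size cannot be read and it says nothing about how much a small change on an aromatic carbon can move the value.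

Compound 4, `CCn1c(CNc2ccccc2)nnc1SCc1nc2cc(F)ccc2o1`, differs from compound 2 by fluoro in place of chloro on an aromatic carbon. Among the compounds with values here, no measured step concerns a change of this kind, and the single unreadable step gives no guide either. From the data alone no step beyond the scatter can be expected in either direction. The expected step from the measured compound to the new one is a step that the limit leaves unreadable from compound 2 to compound 4. Compound 4 is estimated at 3000 nM, within a range from 1000 nM to 15000 nM, and the assay is most likely to report only a limit for it again.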

Compound 4, half-maximal inhibitory concentration: > 1000 nM
Compound 4 ended at the assay's limit; the forecaster's own chance of this, stated with the estimate: 85%; the middle value is on the limit's open side.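

Compound 2 and compound 4 each give only a limit in this assay, so the size of the change from chloro to fluoro cannot be read. All the compounds shown now rest at the same place: the limit of > 1000 nM in this assay, at which 4 of the 4 values shown sit.

What they leave open is how strongly any of them inhibits, and whether any change to the shared core would give a measurable value.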